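The source may hold more compounds than are shown below. What is called first, only, known or untested is meant among the compounds shown, and "the series" means these compounds.

Compound 3 `COc1ccc([C@H]2CC(=O)N(c3ccc(C)c(N)c3)C2)cc1OC1CCCC1` stands at a limit rather than a number: in a functional assay on HEK293 cells (Homo sapiens) for cytotoxicity (a higher number here means that more compound is tolerated, a lower number that less compound is tolerated), compound 3 gives > 10000 nM. Compound 2 `COc1ccc([C@H]2CC(=O)N(c3cccc(O)c3)C2)cc1OC1CCCC1` likewise reaches only a limit in this assay, > 10000 nM. Compound 1 `COc1ccc([C@H]2CC(=O)N(Cc3cccc([N+](=O)[O-])c3)C2)cc1OC1CCCC1` also ends at a limit in this assay, > 10000 nM. The change to compound 4 `COc1ccc([C@H]2CC(=O)N(c3ccccc3C(F)(F)F)C2)cc1OC1CCCC1` is 2-(trifluoromethyl)phenyl in place of 3-amino-4-methylphenyl on an amide-type nitrogen in a ring. Among the measured compounds shown here, the steps that bear on it are a step that the two limits leave unreadable from compound 1 to compound 3, a step that the two limits leave unreadable from compound 2 to compound 3 and a step that the two limits leave unreadable from compound 1 to compound 2; none of them can be sized because of the limit of > 10000 nM in this assay, at which 3 of the 3 values shown sit. With no readable step in the series, the estimated step that the limit leaves unreadable from compound 3 to compound 4 is expected to show no direction beyond the scatter. Compound 4 is therefore expected to give about 15000 nM in this assay, within 7000 nM to 40000 nM, most likely again reported only as a limit.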

Compound 4, half-maximal cytotoxic concentration: > 10000 nM
Compound 4 was reported as a limit; the forecaster's own chance of this, stated with the estimate: 85%; the middle value does not contradict the limit.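

The steps from compound 1, compound 2 and compound 3 to compound 4 cannot be read in this assay, because all four compounds end at a limit: the limit of > 10000 nM in this assay, at which 4 of the 4 values shown sit.

The compounds shown leave open where any of the four would give a numerical value in this assay, and whether the group on the amide-type nitrogen changes that value.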